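Aryl amine swap on the shared core: compound 2 to compound 3

This account rests on a few compounds, and the source may have more. Where it says the series, first, only, none or still open, it means among the compounds named here.

Within the data shown here, in a functional assay on Bel-7402 cells (Homo sapiens) for cytotoxicity, read by MTT assay (a higher number here means a weaker inhibitor, a lower number a stronger inhibitor), compound 2 `Cc1nc(Nc2ccc(Cl)c(Cl)c2)sc1C(=O)/C=C/c1ccccc1` gives 21500 nM, the only number reported in the pair. Compound 1 `Cc1nc(Nc2ccc(Cl)cc2)sc1C(=O)/C=C/c1ccccc1` reaches only the assay limit at > 25000 nM (the limit of > 25000 nM in this assay, at which 1 of the 2 values shown sits). Among the measured compounds shown here, the single measured step, an at least 1.1-fold lower number from compound 1 to compound 2 (0.06 log units; that floor lies within the scatter), stays within the scatter. Compound 3 `Cc1cccc(Nc2nc(C)c(C(=O)/C=C/c3ccccc3)s2)c1` carries 3-methylphenyl in place of 3,4-dichlorophenyl on a nitrogen on an aromatic ring. For the measured compounds named here, no measured step touches a methylphenyl on that nitrogen, and the chlorine step gives no usable direction. For compound 3 no change beyond the scatter is expected in this assay, an estimated step of a 1.2-fold higher number from compound 2 to compound 3 (0.07 log units; within the scatter). Compound 3 is therefore estimated at 25000 nM, within 8000 nM to 80000 nM.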

Compound 3, half-maximal inhibitory concentration: > 25000 nM
Compound 3: no number, only a limit; the forecaster's own chance of this, stated with the estimate: 50%; the middle value sits exactly at the limit.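

In this assay, on these data alone, the swap gives an at least 1.1-fold higher number from compound 2 to compound 3 (0.06 log units; that floor lies within the scatter), so a chlorine-free 3-methylphenyl on this nitrogen shows no readable shift from 3,4-dichlorophenyl, and the true size of the step stays unknown. Compound 3 gives only a limit, as compound 1 does, and the step between these two cannot be read. Most of the aryl amine set now gives no number: the limit of > 25000 nM in this assay, at which 2 of the 3 values shown sit.

Still open, as far as these compounds go, is whether any group on this nitrogen moves the number clearly lower. A phenyl ring carrying an amine or a carboxylic acid would be one test of that.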